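Mirror-Image Pyrrolidine Diol Against Maltase-Glucoamylase

The source may report more compounds than this note shows. Statements on the series, on what has been measured and on what is new or still open speak of the compounds shown alone.

Measured compounds:
- compound 1, `O[C@@H]1[C@@H](O)CN[C@H]1c1ccc(-c2ccccc2)cc1`: 15.6%
- compound 2, `O[C@@H]1[C@@H](O)CN[C@H]1c1ccccc1`: 24.6%
- compound 3, `O[C@@H]1[C@@H](O)CN[C@H]1c1ccc(F)cc1`: 30%

Three compounds share one core and differ only in the group on the aromatic ring. In an assay on lysosomes for inhibition of Maltase-glucoamylase (Homo sapiens), read by spectrophotometry, tested at 1000 uM (on this read-out higher numbers stand for more inhibition at the one concentration tested (going by the name of the read-out) and lower numbers for less inhibition), compound 3 gives the highest of the three numbers. Its nearest neighbour is compound 2, and that gap, a number 5.4 percentage points higher from compound 2 to compound 3 (within the scatter), is within the scatter, so the two cannot be placed in order. The gap to compound 1, a number 14.4 percentage points higher from compound 1 to compound 3 (beyond the scatter), is beyond the scatter, as is a number 9 percentage points higher from compound 1 to compound 2 (within the scatter) only within it.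

Compound 4, `O[C@H]1[C@H](O)CN[C@@H]1c1ccc(F)cc1`, is the mirror image of compound 3: the two compounds have the same atoms and bonds and differ only in configuration as drawn: 3 of 3 stereo elements differ (all stereocentres are inverted: mirror images); a stereocentre at a saturated ring carbon is drawn S in compound 3 and R in compound 4; a stereocentre at a saturated ring carbon is drawn S in compound 3 and R in compound 4; a stereocentre at a saturated ring carbon is drawn S in compound 3 and R in compound 4.

For the measured compounds named here, none of the measured steps bears on this change. Each of them swaps a group on the aromatic ring; none inverts a stereocentre, so the three numbers give no guide to the size or direction of the step. The expectation for compound 4 is therefore uncertain and is set near compound 3 with a wide range, which means an expected step of a number 10 percentage points lower from compound 3 to compound 4 (within the scatter). Compound 4 is expected to give 20% in this assay, between 0% and 45%.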

Compound 4, a percentage reported as inhibition, at one concentration (the size of the read-out at that concentration, not a potency): 13.4%
Compound 4: middle estimate off by 6.6 percentage points, on the high side; low and high end bracket the measured number.
By their numbers in this assay, from the lowest: compounds 4, 1, 2 and 3 (each within the scatter of the next, the first and the last beyond it).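

In this assay, inverting every stereocentre gives a number 16.6 percentage points lower from compound 3 to compound 4 (beyond the scatter). For the compounds shown here, nothing else separates the two structures, so this step can be attributed to configuration alone, because the pair shares every atom and bond: the fact that compounds 3 and 4 differ only in the configuration as drawn The earlier steps only swapped the group on the aromatic ring, so they could not show that the three-dimensional arrangement of the shared core can by itself move this read-out, although this is a single-concentration percentage and not a potency.

The compounds shown leave open whether the mirror-image change acts the same way with hydrogen or phenyl on the aromatic ring, and whether inverting a single stereocentre would do as much as inverting all of them. On these data alone, how a methoxy group or a carboxylic acid in place of the fluoro would behave in either mirror form is also open.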